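A few compounds are considered here, and "the series" means these few. Any claim that something is new, unique, unknown or untested is made for them only; others in the source may bear on it.

Measured compounds in a functional assay on HEK293 cells for antagonist activity at proteinase-activated receptor 4 (Homo sapiens), read by FLIPR and calcium flux, with a stated time of 30 min; on this read-out higher numbers stand for weaker inhibition and lower numbers for stronger inhibition:

Compound 1, `c1ccc(Sc2nn3cc(-c4cc5ccccc5o4)nc3s2)cc1`, gives 1900 nM.
Compound 2, `CCSc1nn2cc(-c3cc4ccccc4o3)nc2s1`, gives 2900 nM.
Compound 3, `CCOc1nn2cc(-c3cc4ccccc4o3)nc2s1`, gives 67 nM.

Compound 3 stands lowest of the three; its nearest neighbour is compound 1, and the step of a 28-fold lower number from compound 1 to compound 3 (1.45 log units; beyond the scatter) shows the size of that gap, while the step of a 43-fold lower number from compound 2 to compound 3 (1.64 log units; beyond the scatter) is larger still. Between the two sulfur-linked compounds the step of a 1.5-fold higher number from compound 1 to compound 2 (0.18 log units; within the scatter) is small.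

Compound 4, `c1ccc2oc(-c3cn4nc(C5CC5)sc4n3)cc2c1`, has not been measured. It differs from compound 3 by cyclopropyl in place of ethoxy on an aromatic carbon. For the measured compounds named here, no measured step replaces ethoxy by a carbon-linked group, so none bears on this change directly. The two large steps seen so far, from compound 1 and from compound 2 to compound 3, show that the group at this position can move this assay a great deal, and that ethoxy stands apart from the sulfur-linked groups. Losing ethoxy is therefore expected to cost activity in this assay, by a step of about a 9.0-fold higher number from compound 3 to compound 4 (0.95 log units; beyond the scatter). Compound 4 is estimated at 600 nM, within a range of 120 nM to 3000 nM.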

Compound 4, half-maximal inhibitory concentration: 530 nM
Beside the measured number, compound 4's estimate is 1.1-fold (0.05 log units) above it; the measured number falls inside the stated range.
By their numbers in this assay, from the lowest: compound 3; then compound 4; then compounds 1 and 2 (each within the scatter of the next).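

Ethoxy and cyclopropyl each count 3 heavy atoms, so this is the first comparison at this position that leaves that count unchanged, and ethoxy still keeps its lead with a 7.9-fold higher number from compound 3 to compound 4 (0.90 log units; beyond the scatter). The cyclopropyl compound also improves on both sulfur-linked compounds, with a 5.5-fold lower number from compound 2 to compound 4 (0.74 log units; beyond the scatter) and a 3.6-fold lower number from compound 1 to compound 4 (0.55 log units; beyond the scatter), so the sulfur-linked groups and ethoxy no longer mark the only two levels seen at this position. No measurement shown accounts for these differences.

The compounds shown leave open whether the lead of ethoxy extends to other oxygen-linked groups such as methoxy or propoxy. They also leave open how an open carbon chain such as propyl, or an amine, would compare with cyclopropyl on the same core.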